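Shortening the ether chain: from hexyloxy to isopropoxy

The source may report more compounds than this note shows. Statements on the series, on what has been measured and on what is new or still open speak of the compounds shown alone.

Three measured compounds share one core and differ only in the chain on the aromatic ether oxygen. In a functional assay for inhibition of Vanilloid receptor (Rattus norvegicus) (a lower number here means a stronger inhibitor, a higher number a weaker inhibitor), compound 1 `CCOc1cc(C(C)(C)C)ccc1C/N=C(\S)NCc1ccc(NS(C)(=O)=O)cc1` gives 1100 nM, compound 2 `CCCCOc1cc(C(C)(C)C)ccc1C/N=C(\S)NCc1ccc(NS(C)(=O)=O)cc1` gives 60 nM, and compound 3 `CCCCCCOc1cc(C(C)(C)C)ccc1C/N=C(\S)NCc1ccc(NS(C)(=O)=O)cc1` gives 150 nM, the second highest of the three numbers. Lengthening the chain gave an 18-fold lower number from compound 1 to compound 2 (1.26 log units; beyond the scatter) and a 7.3-fold lower number from compound 1 to compound 3 (0.87 log units; beyond the scatter), whereas a 2.5-fold higher number from compound 2 to compound 3 (0.40 log units; beyond the scatter). Compound 4 `CC(C)Oc1cc(C(C)(C)C)ccc1C/N=C(\S)NCc1ccc(NS(C)(=O)=O)cc1` carries isopropyl in place of hexyl on an oxygen on an aromatic ring. Within the data shown here, no measured compound has a branched chain, so the three chains only show a short ethoxy well above butoxy and hexyloxy. Because compound 1 gives 1100 nM while compound 2 gives 60 nM, an intermediate chain is expected to fall between them. For compound 4 the expected step is a 2.0-fold higher number from compound 3 to compound 4 (0.30 log units; within the scatter). The estimate for compound 4 is 300 nM, with a range from 70 nM to 1300 nM.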

Compound 4, half-maximal inhibitory concentration: 350 nM
The estimate for compound 4 lay 1.2-fold (0.07 log units) below the measured number; the range from low to high includes it.
By their numbers in this assay, from the lowest: compound 2; then compound 3; then compound 4; then compound 1.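

In this assay the branched isopropyl chain on the ether oxygen keeps part of the gain over the ethyl chain, with a 3.1-fold lower number from compound 1 to compound 4 (0.50 log units; beyond the scatter). It does not reach the longer straight chains, however, showing a 2.3-fold higher number from compound 3 to compound 4 (0.37 log units; beyond the scatter) and a 5.8-fold higher number from compound 2 to compound 4 (0.77 log units; beyond the scatter). No evidence available here accounts for this order. From the compounds shown here alone, what a straight propyl chain would give remains open, so the effect of branching cannot be separated from that of chain length. Going by these compounds, how a cyclopropylmethyl group on the same oxygen would compare also remains open.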